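Swapping a Chlorophenyl for a Difluorophenyl on the Core

A few compounds are considered here, and "the series" means these few. Any claim that something is new, unique, unknown or untested is made for them only; others in the source may bear on it.

Three compounds share one core and differ only in the aromatic group attached to it. Compound 1 `CC(=O)Nc1cccc(C2CCN(CCCn3c(-c4cccc(Cl)c4)nc4ccccc43)CC2)c1` carries a 3-chlorophenyl there; in an assay for displacement of a labelled ligand from melanin-concentrating hormone receptor 1 (Homo sapiens), read by fluorescence (on this read-out higher numbers stand for weaker inhibition and lower numbers for stronger inhibition), compound 1 gives 5 nM, the second highest of the three numbers seen so far. Compound 2 `CC(=O)Nc1cccc(C2CCN(CCCn3c(-c4cccc(C(F)(F)F)c4)nc4ccccc43)CC2)c1` carries a 3-(trifluoromethyl)phenyl instead, and in this assay compound 2 gives 30 nM; a 6.0-fold higher number from compound 1 to compound 2 (0.78 log units; beyond the scatter). Compound 3 `CC(=O)Nc1cccc(C2CCN(CCCn3c(-c4ccc(Cl)cc4Cl)nc4ccccc43)CC2)c1` carries a 2,4-dichlorophenyl, and in this assay compound 3 gives 3 nM; a 1.7-fold lower number from compound 1 to compound 3 (0.22 log units; within the scatter).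

Compound 4 `CC(=O)Nc1cccc(C2CCN(CCCn3c(-c4ccc(F)c(F)c4)nc4ccccc43)CC2)c1` has not yet been measured. Its change from compound 1 is 3,4-difluorophenyl in place of 3-chlorophenyl on an aromatic carbon. Going by the values given here, no measured step makes exactly this exchange. The step to compound 2 shows that replacing the chloro group with a different group can cost a modest amount, while the step to compound 3 shows that a second halogen on the ring is tolerated. Compound 4 is therefore expected to sit near compound 1 or somewhat higher, with an expected 2.4-fold higher number from compound 1 to compound 4 (0.38 log units; beyond the scatter). The estimate for compound 4 in this assay is 12 nM, expected to fall between 4 nM and 40 nM.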

Compound 4, half-maximal inhibitory concentration: 4 nM
Compound 4: the middle estimate sits 3.0-fold (0.48 log units) above what was measured; low and high end bracket the measured number.
By their numbers in this assay, from the lowest: compounds 3, 4 and 1 (each within the scatter of the next); then compound 2.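

In this assay, the 3,4-difluorophenyl group performs on a par with the 3-chlorophenyl group, a 1.3-fold lower number from compound 1 to compound 4 (0.10 log units; within the scatter), and with the 2,4-dichlorophenyl group, a 1.3-fold higher number from compound 3 to compound 4 (0.12 log units; within the scatter). This shows that the aromatic carbon between two ring nitrogen atoms can carry a phenyl ring with no chloro group and stay in the same range, so the loss seen with trifluoromethyl does not follow every replacement of chloro, as a 7.5-fold lower number from compound 2 to compound 4 (0.88 log units; beyond the scatter) makes clear. Nothing available here explains why these groups behave as they do.

The compounds shown leave open whether both fluorines are needed, which a plain phenyl or a single-fluorine ring would test. They also leave open how this position would respond to a phenyl ring carrying an amine or a carboxylic acid.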